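A few compounds are considered here, and "the series" means these few. Any claim that something is new, unique, unknown or untested is made for them only; others in the source may bear on it.

Measured compounds:
- compound 1 `CC(=O)N1CCN(c2ccc(OCC3CCN(C(=O)OC(C)C)CC3)cn2)CC1`: in a functional assay on CHO-K1 cells for agonist activity at Glucose-dependent insulinotropic receptor (Homo sapiens), read by a luciferase reporter, with a stated time of 5 h (a lower number here means that less compound is needed, a higher number that more compound is needed for the effect), compound 1 gives only a limit, > 10000 nM
- compound 2 `CCCS(=O)(=O)N1CCN(c2ccc(OCC3CCN(C(=O)NC(C)(C)C)CC3)cn2)CC1`: in this assay compound 2 gives 800 nM

Among the measured compounds shown here, compound 2 carries the only actual number in this set. For the measured compounds named here, the other measured compound sits at the limit of > 10000 nM in this assay, at which 1 of the 2 values shown sits, which marks a limit of the assay rather than a measured value, so no step between two numbers exists here and nothing can be said about how large a change of this kind has been before.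

Compound 3 `CCCS(=O)(=O)N1CCN(c2ccc(OCC3CCN(C(=O)Nc4ccc(C(C)C)cc4)CC3)cn2)CC1` arises from compound 2 through a single change: 4-isopropylphenyl in place of tert-butyl on an amide-type nitrogen. In words, a 4-isopropylphenyl group takes the place of tert-butyl on an amide-type nitrogen, the nitrogen whose other neighbour is the carbonyl carbon. Going by the values given here, no measured pair shares this change. The expectation rests only on compound 2 and on the size of the group that enters. A step of moderate size is expected, with the direction uncertain; the step from compound 2 to compound 3 is estimated as a 1.6-fold lower number from compound 2 to compound 3 (0.20 log units; within the scatter). Compound 3 is therefore expected to give about 500 nM in this assay, within a range from 100 nM to 3000 nM.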

Compound 3, half-maximal effective concentration: 900 nM
The estimate for compound 3 lay 1.8-fold (0.26 log units) below the measured number; the measured number falls inside the stated range.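

Putting 4-isopropylphenyl in place of tert-butyl on the amide-type nitrogen gives a 1.1-fold higher number from compound 2 to compound 3 (0.05 log units; within the scatter) in this assay and so leaves the two compounds indistinguishable in this measurement. A group of 9 heavy atoms with a six-membered aromatic ring therefore does as well here as a group of 4 heavy atoms with no ring, which compound 2 alone could not show. Nothing available offers a reason for this outcome.

Both groups shown consist of carbon only, so it remains open how the result would look with an amine or a carboxylic acid on the phenyl ring, or with a longer chain such as hexyl on the same nitrogen. One step also cannot tell whether a much smaller group such as methyl, or a pyridine ring in place of the carbon-only ring, would fit the same picture.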